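Amide substituent swap on a shared chromone-acrylamide series

A few compounds are considered here, and "the series" means these few. Any claim that something is new, unique, unknown or untested is made for them only; others in the source may bear on it.

Of the compounds shown here, three have been measured in a functional assay on Huh-7 cells (Homo sapiens) for inhibition, read by MTT assay, with a stated time of 48 h; a lower number here means a stronger inhibitor, a higher number a weaker inhibitor. Compound 1 `COc1ccc2c(=O)c(/C=C/C(=O)NCc3ccc(C)cc3)coc2c1` gives 14300 nM. Compound 2 `Cc1ccccc1NC(=O)/C=C/c1coc2cc(O)ccc2c1=O` gives 11100 nM. Compound 3 `COc1ccc2c(=O)c(/C=C/C(=O)Nc3ccccc3C)coc2c1` gives 26900 nM. Compound 1 and compound 2 lie within the scatter of each other, so no order between them is drawn.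

Two single-point changes connect the measured set. The change 4-methylbenzyl in place of 2-methylphenyl on an amide-type nitrogen produced a 1.9-fold lower number from compound 3 to compound 1 (0.27 log units; within the scatter). The cores of compound 2 and compound 3 differ by hydrogen in place of methyl on an oxygen on an aromatic ring, which made a 2.4-fold higher number from compound 2 to compound 3 (0.38 log units; beyond the scatter).

Compound 4 `Cc1ccc(CNC(=O)/C=C/c2coc3cc(O)ccc3c2=O)cc1` has not yet been measured in this assay. It arises from compound 2 by 4-methylbenzyl in place of 2-methylphenyl on an amide-type nitrogen. This is the same change as that from compound 3 to compound 1: the place lines match word for word, an amide-type nitrogen whose other neighbour is a carbonyl carbon, and only the core differs by hydrogen in place of methyl on an oxygen on an aromatic ring. Going by the values given here, the expected step from compound 2 to compound 4 is a 1.7-fold lower number from compound 2 to compound 4 (0.23 log units; within the scatter), resting on a 1.9-fold lower number from compound 3 to compound 1 (0.27 log units; within the scatter) as the single observed instance of this change. For compound 4 the estimated value in this assay is 6500 nM, with a likely range from 3000 nM to 14000 nM.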

Compound 4, half-maximal inhibitory concentration: > 100000 nM
Compound 4 ended at the assay's limit; the forecaster's own chance of this, stated with the estimate: 5%; middle value at least 15-fold (1.18 log units) from the limit.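

In this assay compound 4 gives > 100000 nM, which is a limit of the assay and not a number. With 4-methylbenzyl in place of 2-methylphenyl on an amide-type nitrogen there is an at least 9.0-fold higher number from compound 2 to compound 4 (0.95 log units; beyond the scatter), and with hydrogen in place of methyl on an oxygen on an aromatic ring there is an at least 6.9-fold higher number from compound 1 to compound 4 (0.84 log units; beyond the scatter), so within these four compounds the first change does not carry from one core to the other: the same change on two cores in this assay, a 1.9-fold lower number (0.27 log units; within the scatter) from compound 3 to compound 1 and an at least 9.0-fold higher number (0.95 log units; beyond the scatter) from compound 2 to compound 4, at least 16-fold (1.22 log units) apart, beyond the scatter of two such steps. The second change depends in the same way on the group on the amide-type nitrogen, but with one pair per core this shows only that the two places do not act independently here, and neither a cause nor a rule for other groups: the same change on two cores in this assay, a 2.4-fold higher number (0.38 log units; beyond the scatter) from compound 2 to compound 3 and an at least 6.9-fold lower number (0.84 log units; beyond the scatter) from compound 4 to compound 1, at least 16-fold (1.22 log units) apart, beyond the scatter of two such steps.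

The compounds shown leave open whether this step is specific to 4-methylbenzyl or extends to other groups on the amide-type nitrogen, such as an unsubstituted benzyl or a longer chain ending in phenyl. On these data alone, it is also open whether ethyl or acetyl on that oxygen, paired with 4-methylbenzyl, would follow methyl or hydrogen.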